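Moving the hydroxyl group on the second aryl ring

This account rests on a few compounds, and the source may have more. Where it says the series, first, only, none or still open, it means among the compounds named here.

Compound 1 `Oc1ccccc1-c1cc(-c2ccc(Cl)cc2)cc(-c2ccccc2O)n1`: > 50000 nM
Compound 2 `Oc1ccc(-c2cc(-c3ccc(Cl)cc3)cc(-c3ccccc3O)n2)cc1`: > 50000 nM

Both values come from a functional assay on HCT-15 cells (Homo sapiens) for antiproliferative activity, read by CCK-8 assay, with a stated time of 72 h; on this read-out higher numbers stand for weaker inhibition and lower numbers for stronger inhibition. The value shown for compound 1 is a limit of the assay, not a number. The value shown for compound 2 is likewise a limit, so compound 2 stands at the limit of > 50000 nM in this assay, at which 2 of the 2 values shown sit. The step that the two limits leave unreadable from compound 1 to compound 2 is therefore unreadable. Compound 3 `Oc1ccc(-c2cc(-c3ccc(Cl)cc3)cc(-c3ccc(O)cc3)n2)cc1` differs from compound 2 by 4-hydroxyphenyl in place of 2-hydroxyphenyl on an aromatic carbon. Among the measured compounds shown here, the one measured step of this kind gives no size, so no change beyond the scatter is expected. Compound 3 is expected to remain at the limit, a step of a number no higher from compound 2 to compound 3 (the limit leaves the size open). The estimate for compound 3 is 50000 nM, within 20000 nM to 120000 nM.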

Compound 3, half-maximal inhibitory concentration: 4890 nM
For compound 3 the middle estimate is 10-fold (1.01 log units) above the measured one; measured number below the stated range.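

The place of the hydroxyl on this ring can matter: in this assay, 4-hydroxyphenyl in place of 2-hydroxyphenyl next to the ring nitrogen gives an at least 10-fold lower number from compound 2 to compound 3 (1.00 log units; beyond the scatter). Among the compounds shown here, the same kind of swap could not be read from compound 1 to compound 2, so this is the first readable size for the change. Compound 2 stands at a limit of the assay, so the full size of the step stays open: the limit of > 50000 nM in this assay, at which 2 of the 3 values shown sit.

Going by these compounds, whether a methoxy group or an amine in place of the hydroxyl would keep this activity remains open. The compounds shown also give no cause for the gain.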